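Fluoro on the carbamate aryl ring in the shared series

The source may report more compounds than this note shows. Statements on the series, on what has been measured and on what is new or still open speak of the compounds shown alone.

Measured compounds:
compound 1, `CCCCCCCCCCCCOc1ccc(NC(=O)Oc2ccccc2F)cc1` — 13 nM
compound 2, `CCCCCCOc1ccc(NC(=O)Oc2ccccc2)cc1` — 31 nM

Both compounds were tested in an assay on H4 cells for inhibition of Fatty-acid amide hydrolase 1 (Homo sapiens); a lower number here means a stronger inhibitor, a higher number a weaker inhibitor. Compound 2 stands at the higher of the two numbers, with 31 nM against 13 nM for compound 1, a gap described as beyond the usual scatter. Compound 1 and compound 2 differ in more than one place, so no single change can be read from that pair.

Compound 3, `CCCCCCOc1ccc(NC(=O)Oc2ccccc2F)cc1`, is not yet measured. Compound 3 differs from compound 2 in one place only: fluoro in place of hydrogen on an aromatic carbon. Going by the values given here, this is the same fluoro that compound 1 carries, but compound 2 and compound 3 share the rest of the structure, so the step is isolated here for the first time. Among the compounds with values here, no measured step of exactly this kind exists.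

The expectation is a step in the direction of a lower number, of modest size, possibly within the scatter: a 1.6-fold lower number from compound 2 to compound 3 (0.19 log units; within the scatter). On that basis compound 3 is estimated at 20 nM, with a range from 8 nM to 50 nM.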

Compound 3, half-maximal inhibitory concentration: 710 nM
For compound 3 the middle estimate is 36-fold (1.55 log units) below the measured one, outside the stated range (above it).
By their numbers in this assay, from the lowest: compound 1; then compound 2; then compound 3.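

In this assay, phenoxy to 2-fluorophenoxy gives a 23-fold higher number from compound 2 to compound 3 (1.36 log units; beyond the scatter) and so marks this ortho place on the six-membered aromatic ring as highly sensitive to the change when the chain is hexyl; this single atom moves the number far more than the opening pair could show. With the fluoro held constant, the chain also matters strongly: hydrogen in place of hexyl, six bonds along the chain from the oxygen on the aromatic ring, gives a 55-fold higher number from compound 1 to compound 3 (1.74 log units; beyond the scatter) and places the two fluoro compounds far apart. Nothing available explains either step.

Still open, from the compounds shown here alone, is how the same fluoro step reads on the longer chain of compound 1, so the dependence of the fluoro effect on chain length cannot yet be judged. Also open, going by these compounds, is whether this sensitivity is specific to fluoro or extends to chloro, methyl or methoxy at the same place on the ring.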